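The source may report more compounds than this note shows. Statements on the series, on what has been measured and on what is new or still open speak of the compounds shown alone.

Measured in a functional assay on A2780 cells (Homo sapiens) for inhibition; a higher number here means a weaker inhibitor, a lower number a stronger inhibitor:
Compound 1 `CCCCCC/C=C/c1cc(C)oc(=O)c1` gives > 50000 nM, a limit of the assay.
Compound 2 `CCCCc1cc(C)oc(=O)c1` gives > 50000 nM, likewise a limit.
Compound 3 `Cc1cc(-c2ccc(C=O)cc2)cc(=O)o1` gives 19200 nM.

Compound 2 stands at the limit of this assay, together with compound 1, as the limit of > 50000 nM in this assay, at which 2 of the 3 values shown sit, records; only compound 3 returns a number. Compound 4 `CCOCCc1cc(C)oc(=O)c1` is the next step from compound 2: ethoxy in place of ethyl on a saturated chain carbon, two bonds along the chain from an aromatic carbon. For the measured compounds named here, no step between measured compounds is available to size this change, and the values of compound 1 and compound 2 show only that both sit at the limit. The expected step of a number no higher from compound 2 to compound 4 (the limit leaves the size open) is none beyond the scatter, with compound 4 most likely again returned as a limit. Compound 4 is estimated at 50000 nM, between 20000 nM and 150000 nM.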

Compound 4, half-maximal inhibitory concentration: > 50000 nM
Compound 4 gave a limit, no number; the forecaster's own chance of this, stated with the estimate: 70%; the middle value sits exactly at the limit.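

Compound 2 and compound 4 both return only a limit in this assay, and no step between them can be read: the limit of > 50000 nM in this assay, at which 3 of the 4 values shown sit.

The compounds shown leave open what ethoxy in place of ethyl does to inhibition in this assay.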